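Replacing methylsulfanyl with tert-butyl in a urea series

The source may hold more compounds than are shown below. What is called first, only, known or untested is meant among the compounds shown, and "the series" means these compounds.

Measured compounds:
compound 1 `Cc1cc(NC(=O)Nc2cc(F)ccc2F)c2ccccc2n1` — 12000 nM
compound 2 `CSc1ccccc1NC(=O)Nc1cc(C)nc2ccccc12` — > 25000 nM

Of the compounds shown here, two have been measured in an ADME assay on HEK293 cells (Homo sapiens) for cytotoxicity, with a stated time of 72 h; on this read-out lower numbers stand for an effect already at smaller amounts and higher numbers for an effect only at larger amounts of compound. Compound 1 `Cc1cc(NC(=O)Nc2cc(F)ccc2F)c2ccccc2n1` gives 12000 nM in this assay. Compound 2 `CSc1ccccc1NC(=O)Nc1cc(C)nc2ccccc12` gives only a limit in this assay, > 25000 nM, so no number is known for it, only that it sits at the limit of > 25000 nM in this assay, at which 1 of the 2 values shown sits.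

Compound 3 `Cc1cc(NC(=O)Nc2ccccc2C(C)(C)C)c2ccccc2n1` has not yet been measured. It differs from compound 2 in one place: tert-butyl in place of methylsulfanyl on an aromatic carbon.

Going by the values given here, no measured step between two compounds that differ in a single place is available, so the size of this change in this assay cannot be read from any earlier pair. Since compound 2 stands only at the limit, compound 3 is expected to stay near that limit, with a step of an at least 1.1-fold lower number from compound 2 to compound 3 (0.05 log units; that floor lies within the scatter) that is no larger than the scatter, if a number is reported at all. On that basis compound 3 is estimated at 22000 nM, within a range from 8000 nM to 60000 nM, in this assay.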

Compound 3, half-maximal effective concentration: > 25000 nM
Compound 3: no number, only a limit; the forecaster's own chance of this, stated with the estimate: 60%; middle value at least 1.1-fold (0.05 log units) from the limit.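

Compound 2 and compound 3 both stand only at a limit in this assay, so no step between them can be read: the limit of > 25000 nM in this assay, at which 2 of the 3 values shown sit.

The compounds shown leave open what actual numbers compound 2 and compound 3 would give, and so whether tert-butyl in place of methylsulfanyl on an aromatic carbon shifts this read-out at all.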